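The source may report more compounds than this note shows. Statements on the series, on what has been measured and on what is new or still open speak of the compounds shown alone.

Values in a functional assay on HeLa cells (Homo sapiens) for antiproliferative activity, read by MTT assay, with a stated time of 72 h; a higher number here means a weaker inhibitor, a lower number a stronger inhibitor:
compound 1 `COc1cc(C(=O)c2sc3ccccc3c2-c2ccccc2)cc(OC)c1OC`: 1900 nM
compound 2 `COc1cc(C(=O)c2sc3ccccc3c2-c2ccc(F)cc2)cc(OC)c1OC`: 3000 nM
compound 3 `COc1ccc(-c2c(C(=O)c3cc(OC)c(OC)c(OC)c3)sc3ccccc23)cc1`: 4200 nM

Compound 1 gives the lowest number of the three; the gap to compound 2 is a 1.6-fold higher number from compound 1 to compound 2 (0.20 log units; within the scatter) and the gap to compound 3 is a 2.2-fold higher number from compound 1 to compound 3 (0.34 log units; beyond the scatter). Compound 4 `COc1cc(C(=O)c2sc3ccccc3c2Nc2ccc(C)cc2)cc(OC)c1OC` differs from compound 1 by (4-methylphenyl)amino in place of phenyl on an aromatic carbon. The measured steps all concern substitution on the ring that is replaced here, and both were small. None of them covers the exchange of the whole group, so their bearing is indirect; the expected step in this assay is modest weakening with broad uncertainty, a 1.8-fold higher number from compound 1 to compound 4 (0.27 log units; within the scatter). Compound 4 is therefore estimated at 3500 nM, within a range of 900 nM to 14000 nM.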

Compound 4, half-maximal inhibitory concentration: 3500 nM
Compound 4: the middle estimate sits on the measured number at the digits printed; the measured number falls inside the stated range.
By their numbers in this assay, from the lowest: compounds 1, 2, 4 and 3 (each within the scatter of the next, the first and the last beyond it).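

In this assay the whole group at this position can be exchanged, with phenyl giving way to (4-methylphenyl)amino and a hydrogen-bond donor entering, while compound 4 stays within the scatter of all three earlier compounds (a 1.8-fold higher number from compound 1 to compound 4 (0.27 log units; within the scatter); a 1.2-fold lower number from compound 3 to compound 4 (0.08 log units; within the scatter); a 1.2-fold higher number from compound 2 to compound 4 (0.07 log units; within the scatter)). The earlier compounds shown here showed only substitution on the phenyl ring. No measurement at hand bears on the cause of this result.

On these data alone, the step joins the amine linker and the methyl group, so the separate part of each remains open. Phenylamino, without the methyl, and the tertiary N-methyl amine would each separate one of these parts.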